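A Difluorophenyl Variant in a Triazole Cytotoxicity Series

This account rests on a few compounds, and the source may have more. Where it says the series, first, only, none or still open, it means among the compounds named here.

Of the compounds shown here, three sharing one core have been measured in a functional assay on PC-12 cells (Rattus norvegicus) for cytotoxicity, read by MTT assay, with stated times of 2 h and 24 h, tested at 5 uM; a higher number here means a stronger effect of the compound at the concentration tested, a lower number a weaker effect. Compound 1 `Oc1cc(C(F)(F)F)ccc1-c1nc(-c2ccccc2O)n(-c2ccc(F)cc2)n1` gives 86.7%. Compound 2 `Oc1cc(C(F)(F)F)ccc1-c1nc(-c2ccccc2O)n(-c2ccc(C(F)(F)F)cc2)n1` gives 90.5%, and compound 3 `Oc1cc(C(F)(F)F)ccc1-c1nc(-c2ccccc2O)n(-c2cccc(Cl)c2)n1` gives 92.7%. Compound 3 thus sits at the top of the three numbers, yet both of its gaps are within the scatter: a number 6 percentage points higher from compound 1 to compound 3 (within the scatter) and a number 2.2 percentage points higher from compound 2 to compound 3 (within the scatter), so no real separation can be claimed among them.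

Compound 4 `Oc1cc(C(F)(F)F)ccc1-c1nc(-c2ccccc2O)n(-c2ccc(F)cc2F)n1` has not yet been measured. It differs from compound 3 in this way: 2,4-difluorophenyl in place of 3-chlorophenyl on an aromatic nitrogen. The two steps that bear on this change are the swaps of the aryl group on the aromatic nitrogen, from compound 1 to compound 3 and from compound 2 to compound 3, and both stayed within the scatter. Varying this aryl group among fluoro, trifluoromethyl and chloro substituents therefore did not move the read-out beyond noise, and the expected step of a number 2.7 percentage points lower from compound 3 to compound 4 (within the scatter) is likewise none beyond the scatter. Compound 4 is estimated to give 90%, with a range from 80% to 99%.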

Compound 4, a percentage reported as activity, at one concentration (the size of the read-out at that concentration, not a potency): 83.5%
For compound 4 the middle estimate is 6.5 percentage points above the measured one, and the stated range covers the measured number.
By their numbers in this assay, from the lowest: compounds 4, 1, 2 and 3 (each within the scatter of the next).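

Putting 2,4-difluorophenyl on the aromatic nitrogen gives no separation in this assay from any earlier compound, with a number 9.2 percentage points lower from compound 3 to compound 4 (within the scatter) and a number 7 percentage points lower from compound 2 to compound 4 (within the scatter) and a number 3.2 percentage points lower from compound 1 to compound 4 (within the scatter) as the three steps. Among these compounds, the last of these adds a fluoro in place of hydrogen on an aromatic carbon of the aryl group, a kind of change the earlier compounds did not include, and it too stays within the scatter. No evidence is available that would explain any of these numbers. The compounds shown leave open whether an amine or a carboxylic acid on this phenyl ring, or a benzyl group in its place on the aromatic nitrogen, would separate from these four. They also leave open how these compounds compare at other concentrations.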